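A few compounds are considered here, and "the series" means these few. Any claim that something is new, unique, unknown or untested is made for them only; others in the source may bear on it.

Measured so far in an assay on isolated protein for antagonist activity at Substance-P receptor (Homo sapiens); on this read-out lower numbers stand for stronger inhibition and higher numbers for weaker inhibition:
Compound 1, `FC(F)(F)c1cc(COCC2(c3ccccc3)CCC(N3CCCC3)CC2)cc(C(F)(F)F)c1`, gives 120 nM.
Compound 2, `CN1CCN(C2CCC(COCc3cc(C(F)(F)F)cc(C(F)(F)F)c3)(c3ccccc3)CC2)CC1`, gives 120 nM.

Compound 2 stands level with compound 1 at the digits shown; the step of no change at the digits printed from compound 1 to compound 2 (within the scatter) lies within the usual scatter, so the two values cannot be told apart. Compound 3, `CN(C)C1CCC(COCc2cc(C(F)(F)F)cc(C(F)(F)F)c2)(c2ccccc2)CC1`, has not yet been measured. It differs from compound 2 by dimethylamino in place of 4-methylpiperazin-1-yl on a saturated ring carbon. Among the compounds with values here, the only measured step that bears on this change is the one from compound 1 to compound 2, in which one amine at the same saturated ring carbon was exchanged for another and no change at the digits printed from compound 1 to compound 2 (within the scatter) resulted. On that single precedent a further exchange of the amine at this position is expected to leave this assay unchanged beyond the scatter, with no change at the digits printed from compound 2 to compound 3 (within the scatter) as the estimated step. Compound 3 is therefore expected to give about 120 nM, within a range from 50 nM to 300 nM.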

Compound 3, half-maximal inhibitory concentration: 48 nM
Compound 3: the middle estimate sits 2.5-fold (0.40 log units) above what was measured; the measured number lies below the stated range.
By their numbers in this assay, from the lowest: compound 3; then compounds 1 and 2 (each within the scatter of the next).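

In this assay, dimethylamino in place of 4-methylpiperazin-1-yl gives a 2.5-fold lower number from compound 2 to compound 3 (0.40 log units; beyond the scatter) and, in place of pyrrolidin-1-yl, gives a 2.5-fold lower number from compound 1 to compound 3 (0.40 log units; beyond the scatter) in the same direction. The position therefore responds to the choice of amine, which the pair of ring amines in compound 1 and compound 2 had not shown. No evidence at hand accounts for the lower number.

Dimethylamino differs from both ring amines in having no ring and in having fewer heavy atoms, so the compounds shown cannot separate these two differences. An open-chain amine such as diethylamino, or a smaller one such as methylamino, would show whether the open chain or the size of the group goes with the lower number.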